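This account rests on a few compounds, and the source may have more. Where it says the series, first, only, none or still open, it means among the compounds named here.

Of the compounds shown here, two have so far been measured in a functional assay (Pituitary gland cell) with Rattus norvegicus as the target; on this read-out higher numbers stand for an effect only at larger amounts of compound and lower numbers for an effect already at smaller amounts. Compound 1 `CC(C)(N)CC(=O)N[C@@H]1CCc2ccccc2N(Cc2ccc(-c3ccccc3-c3nnn(Cc4ccccc4)n3)cc2)C1=O` gives 1 uM in this assay, and compound 2 `CC(C)(N)CC(=O)N[C@@H]1CCc2ccccc2N(Cc2ccc(-c3ccccc3C(N)=O)cc2)C1=O` gives 0.08 uM. Within the data shown here, the one step between them, a 13-fold lower number from compound 1 to compound 2 (1.10 log units; beyond the scatter), leaves compound 2 with the lowest of the two numbers, and compound 1 is its only neighbour, a large gap away. Compound 3 `CC(C)(N)CC(=O)N[C@@H]1CCc2ccccc2N(Cc2ccc(-c3ccccc3S(=O)(=O)NC(=O)c3ccccc3)cc2)C1=O` differs from compound 2 by benzoylsulfamoyl in place of carbamoyl on an aromatic carbon. Among the measured compounds shown here, the only measured step that bears on this change is the one from compound 1 to compound 2, in which a small carbamoyl took the place of a much larger group and the number fell by a large amount. Compound 3 returns to a large group at that place, so the step from compound 2 to compound 3 is expected to be sizeable and upward, estimated as a 6.3-fold higher number from compound 2 to compound 3 (0.80 log units; beyond the scatter). The estimate for compound 3 is therefore 0.5 uM, expected to lie between 0.1 uM and 3 uM.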

Compound 3, concentration for half-maximal effect: 3 uM
Compound 3: middle estimate off by 6.0-fold (0.78 log units), on the low side; the measured number falls inside the stated range.
By their numbers in this assay, from the lowest: compound 2; then compound 1; then compound 3.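

In this assay, the rise seen with 2-benzyl-2H-tetrazol-5-yl is not unique to that group: benzoylsulfamoyl on this aromatic carbon gives a 38-fold higher number from compound 2 to compound 3 (1.57 log units; beyond the scatter), so both large groups shown lie well above carbamoyl. The two large groups are not interchangeable either, since exchanging one for the other gives a 3.0-fold higher number from compound 1 to compound 3 (0.48 log units; beyond the scatter), a modest step compared with those from carbamoyl. Nothing measured here explains either step.

As far as these compounds go, it remains open whether a carboxylic acid or an unsubstituted tetrazole at this place would stay near compound 2 or move towards compound 1 and compound 3. An unsubstituted sulfamoyl would show how much of the step to compound 3 goes with the benzoyl part and how much with the sulfonyl link.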